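Sulfamoyl to methylsulfonyl swap in an anilino-aminopyrimidine series

The source may hold more compounds than are shown below. What is called first, only, known or untested is meant among the compounds shown, and "the series" means these compounds.

Measured compounds:
- compound 1 `Cc1cnc(Nc2ccc(S(C)(=O)=O)cc2)nc1Nc1nc2ccccc2s1`, in a functional assay on MCF7 cells (Homo sapiens) for antiproliferative activity, read by MTT assay, with a stated time of 48 h (a lower number here means a stronger inhibitor, a higher number a weaker inhibitor), compound 1 gives 6550 nM
- compound 2 `NS(=O)(=O)c1ccc(Nc2ncc(F)c(Nc3nc4ccc(Cl)cc4s3)n2)cc1`, in this assay compound 2 gives 8340 nM
- compound 3 `Cc1cnc(Nc2ccc(S(N)(=O)=O)cc2)nc1Nc1nc2ccccc2s1`, for which this assay reports only a limit, > 50000 nM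

Compound 1 and compound 2 sit within the scatter of each other in this assay. Compound 3 sits at the limit of this assay (the limit of > 50000 nM in this assay, at which 1 of the 3 values shown sits), so its number is not known beyond that.

For the measured compounds named here, the one measured step is the change (methyl in place of amino on a sulfonyl sulfur). It gives an at least 7.6-fold lower number from compound 3 to compound 1 (0.88 log units; beyond the scatter). The step is only a lower bound because compound 3 sits at the limit (the limit of > 50000 nM in this assay, at which 1 of the 3 values shown sits); the true drop may be larger.

Compound 4 `CS(=O)(=O)c1ccc(Nc2ncc(F)c(Nc3nc4ccc(Cl)cc4s3)n2)cc1` is not yet measured. It differs from compound 2 by methyl in place of amino on a sulfonyl sulfur. This is the same change as from compound 3 to compound 1, made at the same place, on a sulfonyl sulfur whose other neighbour is an aromatic carbon. The difference between the core of compound 2 and the core of compound 3 is not broken down here.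

Given that the same change carried compound 3 to compound 1 with an at least 7.6-fold lower number from compound 3 to compound 1 (0.88 log units; beyond the scatter), compound 4 is expected to move in the same direction from compound 2, by an estimated 7.0-fold lower number from compound 2 to compound 4 (0.84 log units; beyond the scatter). For compound 4 the estimate in this assay is 1200 nM, expected to fall between 300 nM and 5000 nM.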

Compound 4, half-maximal inhibitory concentration: > 50000 nM
Compound 4: only a limit was reported; the forecaster's own chance of this, stated with the estimate: 2%; at least 41-fold (1.61 log units) between middle value and limit.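

In this assay, methyl in place of amino on a sulfonyl sulfur gives an at least 5.9-fold higher number from compound 2 to compound 4 (0.77 log units; beyond the scatter), so the change does not keep its direction from one core to the other: the same change on two cores in this assay, an at least 7.6-fold lower number (0.88 log units; beyond the scatter) from compound 3 to compound 1 and an at least 5.9-fold higher number (0.77 log units; beyond the scatter) from compound 2 to compound 4, at least 45-fold (1.66 log units) apart, beyond the scatter of two such steps

Compound 4 gives > 50000 nM, which is a limit of the assay and not a number, so this step is a lower bound and its true size stays unknown, and compound 3 at the end of the earlier step stands at the same limit: the limit of > 50000 nM in this assay, at which 2 of the 4 values shown sit.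

Within these four compounds, then, the outcome of the sulfamoyl to methylsulfonyl swap differs with the core, and a result on one core gave no safe reading for the other; the data do not show which feature of the cores is responsible, nor whether this holds beyond the two pairs.

Still open, on these data alone, is which difference between the core of compound 2 and the core of compound 3, the fluorine against the methyl or the chlorine, goes with the reversal. Also open, as far as these compounds go, is how other groups on the sulfonyl sulfur, such as ethyl or dimethylamino, or a carboxylic acid in place of the whole sulfamoyl, would behave on either core.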